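The source may hold more compounds than are shown below. What is called first, only, known or untested is meant among the compounds shown, and "the series" means these compounds.

Working notes on the series, values in a functional assay on MGC-803 cells (Homo sapiens) for cytotoxicity, read by MTT assay, with a stated time of 48 h; a higher number here means a weaker inhibitor, a lower number a stronger inhibitor:

- compound 1 `CC1=NN(C(=O)CCc2ccccc2)C(c2cc(Br)ccc2O)C1`: 21200 nM
- compound 2 `CC1=NN(C(=O)CN2CCCCC2)C(c2ccccc2O)C1`: 4310 nM
- compound 3 `CC(=O)Oc1ccccc1C1CC(C)=NN1C(=O)CN1CCCCC1`: 4890 nM

Compound 3 lies within the scatter of compound 2, and the two together stand at the lower end of the three numbers. Compound 1 is the clear outlier, with a higher number beyond the scatter.

The next entry is compound 4 `CC(=O)Oc1ccccc1C1CC(C)=NN1C(=O)CCl`, which is compound 3 with chloro in place of piperidin-1-yl on a saturated chain carbon bound to a carbonyl carbon.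

Among the compounds with values here, the only measured step between compounds differing in one place is a 1.1-fold higher number from compound 2 to compound 3 (0.05 log units; within the scatter). That step is acetyl in place of hydrogen on an oxygen on an aromatic ring, which is not the place changed here, so it says little about the new change. It does suggest that the acetyl carried over from compound 3 need not shift the number.

Within the data shown here, no measured step removes the piperidin-1-yl alone. Compound 1 also lacks it and gives 21200 nM, but it differs in other places too, so it supports only a lean towards a higher number in this assay. Among the measured compounds shown here, the best guess is therefore no step clearly beyond the scatter, with wide uncertainty.

The estimated step is a 1.5-fold higher number from compound 3 to compound 4 (0.19 log units; within the scatter). For compound 4 the expected value is 7500 nM, with an expected range of 2000 nM to 28000 nM.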

Compound 4, half-maximal inhibitory concentration: 3010 nM
For compound 4 the middle estimate is 2.5-fold (0.40 log units) above the measured one; the range from low to high includes it.
By their numbers in this assay, from the lowest: compounds 4, 2 and 3 (each within the scatter of the next); then compound 1.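

In this assay, within the data shown here, the position now has a measured step of its own, (a 1.6-fold lower number from compound 3 to compound 4 (0.21 log units; within the scatter)), where the earlier compounds offered only a step at the oxygen on the aromatic ring. On a saturated chain carbon bound to a carbonyl carbon, the piperidin-1-yl with its six-membered non-aromatic ring can give way to a single chloro atom with the number staying within the scatter, so with the acetyl in place the piperidin-1-yl is not required for a value of this size. Nothing measured here accounts for this result.

From the compounds shown here alone, the change is read on the acetyl compounds only, so whether chloro in place of piperidin-1-yl behaves the same way with hydrogen on that oxygen, as in compound 2, remains open. Also open, going by these compounds, is whether other groups on this carbon, such as morpholin-4-yl, an open-chain dimethylamino or a carboxylic acid on a longer chain, would stay within the scatter or move the number beyond it.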